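The source may report more compounds than this note shows. Statements on the series, on what has been measured and on what is new or still open speak of the compounds shown alone.

In a functional assay on SH-SY5Y cells (Homo sapiens) for inhibition, read by sulforhodamine B assay (a higher number here means a weaker inhibitor, a lower number a stronger inhibitor), three compounds with the same core differ in the group on a saturated chain carbon bound to a triple-bonded carbon. Compound 1 `COC(=O)CC/C(C)=C/Cc1c(OC)c(C)c2c(c1OCC#CCN1CCCc3ccccc31)C(=O)OC2` gives 9570 nM, compound 2 `COC(=O)CC/C(C)=C/Cc1c(OC)c(C)c2c(c1OCC#CCN1CCC(Cc3ccccc3)CC1)C(=O)OC2` gives 24500 nM, and compound 3 `CCCCNc1ccc(CC#CCOc2c(C/C=C(\C)CCC(=O)OC)c(OC)c(C)c3c2C(=O)OC3)cc1` gives 5960 nM. Compound 3 therefore stands level with compound 1 within the scatter, as a 1.6-fold lower number from compound 1 to compound 3 (0.21 log units; within the scatter) shows, while the number for compound 2 lies beyond the scatter above that of compound 3.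

The next compound is compound 4 `COC(=O)CC/C(C)=C/Cc1c(OC)c(C)c2c(c1OCC#CCN1CCC(C(=O)OC)CC1)C(=O)OC2`, where 4-(methoxycarbonyl)piperidin-1-yl takes the place of 4-(butylamino)phenyl: 4-(methoxycarbonyl)piperidin-1-yl in place of 4-(butylamino)phenyl on a saturated chain carbon bound to a triple-bonded carbon. Going by the values given here, only one measured step touches this place, a 1.6-fold lower number from compound 1 to compound 3 (0.21 log units; within the scatter), and it involves a different pair of groups, so it offers only a weak guide. It does show one exchange at this place that moved the number no further than the scatter. The closer comparison is compound 2, which also carries a six-membered non-aromatic ring with 1 hetero atom here and gives 24500 nM. A moderate move toward a weaker inhibitor is therefore expected, slightly beyond the scatter, as a 2.3-fold higher number from compound 3 to compound 4 (0.37 log units; beyond the scatter). For compound 4 the estimated value is 14000 nM, with an expected range from 5500 nM to 35000 nM.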

Compound 4, half-maximal inhibitory concentration: 41200 nM
Beside the measured number, compound 4's estimate is 2.9-fold (0.47 log units) below it; the whole stated range lies below it.
By their numbers in this assay, from the lowest: compounds 3 and 1 (each within the scatter of the next); then compounds 2 and 4 (each within the scatter of the next).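

In this assay the exchange at this saturated chain carbon bound to a triple-bonded carbon now shows a clear effect, since 4-(methoxycarbonyl)piperidin-1-yl in place of 4-(butylamino)phenyl gives a step beyond the scatter (a 6.9-fold higher number from compound 3 to compound 4 (0.84 log units; beyond the scatter)), and the exchange for 1,2,3,4-tetrahydroquinolin-1-yl does the same (a 4.3-fold higher number from compound 1 to compound 4 (0.63 log units; beyond the scatter)). The two compounds carrying a six-membered non-aromatic ring with 1 hetero atom here stand level with each other (a 1.7-fold higher number from compound 2 to compound 4 (0.23 log units; within the scatter)), so methoxycarbonyl in place of benzyl on the saturated ring carbon leaves the number within the scatter, and among these four compounds both lie beyond the scatter above compound 3. Nothing shown here offers an explanation for these differences.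

On these data alone, whether a carboxylic acid or an amide in place of the methoxycarbonyl would leave compound 4 in the same range stays open. So does the question of whether a shorter or longer chain on the amine of the 4-(butylamino)phenyl group would shift the number of compound 3 at all.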